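The source may report more compounds than this note shows. Statements on the series, on what has been measured and on what is new or still open speak of the compounds shown alone.

Measured so far:
Compound 1 `CC(O)(C(=O)Nc1ccc(S(=O)(=O)c2ccccc2)c(C#N)c1)C(F)(F)F`: 3800 nM
Compound 2 `CC(O)(C(=O)Nc1ccc(S(=O)(=O)c2cccc(O)c2)cc1)C(F)(F)F`: 18000 nM

Of the compounds shown here, two have been measured in a functional assay (Cavia porcellus) with sulfonylurea receptors; K-ATP channels (Homo sapiens) as the target; a lower number here means a stronger inhibitor, a higher number a weaker inhibitor. Compound 1 gives 3800 nM, and compound 2 gives 18000 nM. Compound 2 thus stands at the higher of the two numbers, and its gap to compound 1 lies beyond the usual scatter, so compound 1 is the stronger inhibitor of the pair. Within the data shown here, no step between compounds differing in a single place is available, since the two differ in more than one place.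

Compound 3 `CC(O)(C(=O)Nc1ccc(S(=O)(=O)c2ccc([N+](=O)[O-])cc2)cc1)C(F)(F)F` has not yet been measured. It differs from compound 2 by 4-nitrophenyl in place of 3-hydroxyphenyl on a sulfonyl sulfur. Among the measured compounds shown here, no measured step shows how this change plays out. Compound 1, which also lacks the 3-hydroxyphenyl, gives 3800 nM, which points towards a lower number for compound 3. Compound 3 is therefore expected to show a step of a 2.3-fold lower number from compound 2 to compound 3 (0.35 log units; beyond the scatter) in this assay, a moderate move toward a lower number. The estimated value for compound 3 is 8000 nM, with an expected range from 2000 nM to 30000 nM.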

Compound 3, half-maximal inhibitory concentration: > 30000 nM
Compound 3: only a limit was reported; the forecaster's own chance of this, stated with the estimate: 10%; at least 3.7-fold (0.57 log units) between middle value and limit.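

In this assay compound 3 gives > 30000 nM, which is a limit and not a number. Among these compounds, putting 4-nitrophenyl in place of 3-hydroxyphenyl on the sulfonyl sulfur gives the first step in one place, an at least 1.6-fold higher number from compound 2 to compound 3 (0.22 log units; that floor lies within the scatter), so this change shows no gain in inhibition, while the floor of the step is too small to establish a loss. Only the lower edge of the step is known, and its full size stays undetermined: the limit of > 30000 nM in this assay, at which 1 of the 3 values shown sits.

The compounds shown leave open whether the step belongs to the nitro group itself or to its place on the ring, as the two groups differ in both. They also do not tell how an amine or a carboxylic acid on that ring would read in this assay.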